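Turning a drawn stereocentre: compound 2 to compound 4

This account rests on a few compounds, and the source may have more. Where it says the series, first, only, none or still open, it means among the compounds named here.

Measured so far in a functional assay on PC-3 cells (Homo sapiens) for antiproliferative activity, read by MTT assay, with a stated time of 72 h, tested at 5 uM; on this read-out lower numbers stand for less inhibition and higher numbers for more inhibition at the one concentration tested (going by the name of the read-out):
compound 1 `CCOC(=O)/C(C#N)=C(/NNC(=O)c1cc(OC)c(OC)c(OC)c1)N[C@H](C)c1ccccc1` gives 32.1%
compound 2 `CCOC(=O)/C(C#N)=C(/Nc1ccc(C(F)(F)F)cc1)N[C@@H](C)c1ccccc1` gives 49.1%
compound 3 `CCOC(=O)/C(C#N)=C(/Nc1ccc([N+](=O)[O-])cc1)N[C@@H](C)c1ccccc1` gives 0.7%

Among the measured compounds shown here, compound 2 stands highest of the three; compound 1 sits lower, beyond the scatter, and the single step of one change shows a number 48.4 percentage points lower from compound 2 to compound 3 (beyond the scatter), a large drop. The unmeasured compound 4 `CCOC(=O)/C(C#N)=C(/Nc1ccc(C(F)(F)F)cc1)N[C@H](C)c1ccccc1` differs from compound 2 in this way: the two compounds have the same atoms and bonds and differ only in configuration as drawn: 1 of 2 stereo elements differ; a stereocentre at a saturated chain carbon is drawn S in compound 2 and R in compound 4. For the measured compounds named here, no measured step turns a stereocentre alone, so no step bears directly on it; compound 1 carries the other drawn configuration but also a different group, so it cannot separate the two effects. Such a change can leave the result unchanged or move it far either way, so a broad range is expected. For compound 4 the estimate is 35%, between 5% and 60%, an expected step of a number 14.1 percentage points lower from compound 2 to compound 4 (beyond the scatter).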

Compound 4, a percentage reported as inhibition, at one concentration (the size of the read-out at that concentration, not a potency): 59.4%
Beside the measured number, compound 4's estimate is 24.4 percentage points below it; low and high end bracket the measured number.
By their numbers in this assay, from the lowest: compound 3; then compound 1; then compound 2; then compound 4.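

In this assay, turning the stereocentre at the saturated chain carbon from S to R gives a number 10.3 percentage points higher from compound 2 to compound 4 (beyond the scatter). Among the compounds shown here, this is the first comparison to isolate configuration, which compound 1 could not do, and it shows that this carbon's drawn arrangement alone can shift the result beyond the scatter. The shift can be assigned to that carbon because no other part changes: the fact that compounds 2 and 4 differ only in the configuration as drawn.

Going by these compounds, whether R also gives the higher number with another aromatic group, such as the nitro of compound 3, remains open. So does the effect of an ethyl group on that carbon.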